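The source may report more compounds than this note shows. Statements on the series, on what has been measured and on what is new or still open speak of the compounds shown alone.

Measured so far in a functional assay on HEK293 cells for negative allosteric modulation of metabotropic glutamate receptor 5 (Homo sapiens), read by FLIPR and calcium flux; a lower number here means a stronger inhibitor, a higher number a weaker inhibitor:
compound 1 `Cc1cccc(C#Cc2ccc3c(n2)CCN(C)C3=O)c1` gives 2.9 nM
compound 2 `CN1CCc2nc(C#Cc3cccc(Cl)c3)ccc2C1=O` gives 22 nM

Compound 2 stands at the highest of the two numbers; its nearest neighbour is compound 1, and the step of a 7.6-fold higher number from compound 1 to compound 2 (0.88 log units; beyond the scatter) lies beyond the scatter. Compound 3 `COc1cccc(C#Cc2ccc3c(n2)CCN(C)C3=O)c1` is not yet measured. It differs from compound 2 by methoxy in place of chloro on an aromatic carbon. Within the data shown here, no measured step involves a methoxy group, so only the one known exchange at this aromatic carbon, a 7.6-fold higher number from compound 1 to compound 2 (0.88 log units; beyond the scatter), gives a sense of scale. A step of similar or smaller size, in either direction, is expected, a 1.4-fold higher number from compound 2 to compound 3 (0.13 log units; within the scatter). Compound 3 is estimated at 30 nM, with a range of 8 nM to 120 nM.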

Compound 3, half-maximal inhibitory concentration: 293 nM
Compound 3: middle estimate off by 9.8-fold (0.99 log units), on the low side, and the stated range ends below it.
By their numbers in this assay, from the lowest: compound 1; then compound 2; then compound 3.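

In this assay this aromatic carbon proves far more sensitive than the chloro-for-methyl exchange alone showed: methoxy costs more against chloro (a 13-fold higher number from compound 2 to compound 3 (1.12 log units; beyond the scatter)) and much more against methyl (a 100-fold higher number from compound 1 to compound 3 (2.00 log units; beyond the scatter)). Among these three groups, methoxy gives the weakest inhibitor, with both of its steps beyond the scatter. Nothing available explains the size of this loss.

Still open, from the compounds shown here alone, is whether a hydroxyl or an ethyl group on this carbon would fall nearer methyl or nearer methoxy. Also open, going by these compounds, is whether methoxy would bring a similar loss elsewhere on this ring.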